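The source may hold more compounds than are shown below. What is called first, only, known or untested is meant among the compounds shown, and "the series" means these compounds.

Measured so far in an assay on HEK293 cells for inhibition of solute carrier family 12 member 2 (Homo sapiens), read by fluorescence, with a stated time of 30 min, tested at 100 uM; a lower number here means a weaker effect, a higher number a stronger effect of the compound at the concentration tested:
compound 1, `CCCCCCNc1ccc([N+](=O)[O-])cc1S(=O)(=O)N(C)C`, gives 4.9%
compound 2, `CCCCCCNc1ccc(C(=O)O)cc1S(N)(=O)=O`, gives 4.9%
compound 3, `CCCCCCNc1ccc(C(=O)O)cc1S(=O)(=O)N(C)C`, gives 19.8%

Compound 3 stands highest of the three numbers in this assay; compound 1 and compound 2 sit the same distance beneath it, both beyond the scatter. The two single-place steps both lead into compound 3: a number 14.9 percentage points higher from compound 1 to compound 3 (beyond the scatter) and a number 14.9 percentage points higher from compound 2 to compound 3 (beyond the scatter). Both steps are modest and both concern the shared core, one the group on the aromatic carbon, the other the group on the sulfonyl sulfur. Neither touches the hexyl chain on the ring nitrogen.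

Compound 4, `CN(C)S(=O)(=O)c1cc(C(=O)O)ccc1NCCCC(F)(F)F`, is not yet measured. It differs from compound 3 only in that chain: trifluoromethyl in place of propyl on a saturated chain carbon, three bonds along the chain from a nitrogen on an aromatic ring. Among the compounds with values here, no measured step alters the chain, so there is no step in this set to scale from; the two steps that are known concern other parts of compound 3 and say nothing about the chain. The expectation is therefore a change of no size beyond the scatter in either direction, and a number 1.8 percentage points lower from compound 3 to compound 4 (within the scatter) is what the estimate amounts to. For compound 4 the expected value in this assay is 18%, with a range from 5% to 32%.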

Compound 4, a percentage reported as inhibition, at one concentration (the size of the read-out at that concentration, not a potency): 1.9%
Compound 4: middle estimate off by 16.1 percentage points, on the high side, and the stated range ends above it.
By their numbers in this assay, from the lowest: compounds 4, 1 and 2 (each within the scatter of the next); then compound 3.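

In this assay, the hexyl chain is now shown to matter: a number 17.9 percentage points lower from compound 3 to compound 4 (beyond the scatter), a step printed as modest, like the two already seen on the aromatic carbon and the sulfonyl sulfur. Within the data shown here, earlier compounds kept the chain fixed, so this is the first reading at a saturated chain carbon, three bonds along the chain from a nitrogen on an aromatic ring, and the change of hexyl to 4,4,4-trifluorobutyl does not leave the read-out at this concentration intact. With this step, each of the three single-place differences shown around compound 3 goes with a lower number, beyond the scatter, and none goes against that, while no measurement shown accounts for the drop.

The change replaces propyl with trifluoromethyl in one move, so the compounds shown do not separate the effect of the fluorine atoms from that of the shorter carbon chain; a plain butyl chain at this place would pull the two apart. Also open, as far as these compounds go, is how a longer chain, or a chain ending in an amine or a carboxylic acid, would read against compound 3 in this assay.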